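The source may report more compounds than this note shows. Statements on the series, on what has been measured and on what is new or still open speak of the compounds shown alone.

In a functional assay on HCT-116 cells (Homo sapiens) for antiproliferative activity, read by resazurin assay, with a stated time of 5 days (a higher number here means a weaker inhibitor, a lower number a stronger inhibitor), compound 1 `Cc1ccc(C(=O)NCc2ccc3cc(C(=O)NO)sc3c2F)s1` gives 120 nM and compound 2 `O=C(NCc1ccc2cc(C(=O)NO)sc2c1F)c1ccco1` gives 90 nM while compound 3 `COc1ccccc1C(=O)NCc1ccc2cc(C(=O)NO)sc2c1F` gives 1200 nM and so stands as the weakest of the three. Compound 4 `CN(C)c1ccc(C(=O)NCc2ccc3cc(C(=O)NO)sc3c2F)cc1` carries 4-(dimethylamino)phenyl in place of 2-methoxyphenyl on a carbonyl carbon. Within the data shown here, no measured step makes this exchange directly, so the evidence is indirect. Exchanging 5-methylthiophen-2-yl for furan-2-yl stays within the scatter (a 1.3-fold lower number from compound 1 to compound 2 (0.12 log units; within the scatter)). Bringing in 2-methoxyphenyl gives much larger steps (a 10-fold higher number from compound 1 to compound 3 (1.00 log units; beyond the scatter) and a 13-fold higher number from compound 2 to compound 3 (1.12 log units; beyond the scatter)). Removing that group from compound 3 might therefore recover part of that loss, but both better compounds carry five-membered rings, and compound 4 keeps a six-membered one, so only partial recovery is expected. A moderate step towards a lower number is expected, estimated as (a 3.4-fold lower number from compound 3 to compound 4 (0.54 log units; beyond the scatter)) with wide uncertainty. The expected value for compound 4 is 350 nM (estimated range 100 nM to 1200 nM).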

Compound 4, half-maximal inhibitory concentration: 60 nM
Beside the measured number, compound 4's estimate is 5.8-fold (0.77 log units) above it, outside the stated range (below it).
By their numbers in this assay, from the lowest: compounds 4, 2 and 1 (each within the scatter of the next); then compound 3.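

In this assay, a six-membered aromatic ring on the carbonyl carbon does not by itself bring a high number, as the exchange of 2-methoxyphenyl for 4-(dimethylamino)phenyl gives a 20-fold lower number from compound 3 to compound 4 (1.30 log units; beyond the scatter). The five-membered rings are therefore not required at this position: 4-(dimethylamino)phenyl stands level with furan-2-yl, with a 1.5-fold lower number from compound 2 to compound 4 (0.18 log units; within the scatter), and with 5-methylthiophen-2-yl, with a 2.0-fold lower number from compound 1 to compound 4 (0.30 log units; within the scatter). Nothing available explains the gap between the two substituted phenyl groups.

The compounds shown leave open whether the large step follows from the change of methoxy to dimethylamino or from the different place of the substituent on the ring, since both change together. A 4-methoxyphenyl or an unsubstituted phenyl group on the same carbonyl carbon would separate these two changes.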